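Triazole Ethers on a Bicyclic Ketone Core

The source may hold more compounds than are shown below. What is called first, only, known or untested is meant among the compounds shown, and "the series" means these compounds.

Three compounds built on the same bicyclic ketone core, each carrying a triazole ether, have been tested in a functional assay on MDA-MB-231 cells (Homo sapiens) for cytotoxicity, read by MTT assay, with a stated time of 48 h; a lower number here means a stronger inhibitor, a higher number a weaker inhibitor. Compound 1 `O=C1C[C@H](OCc2cn(Cc3ccccc3)nn2)[C@H]2CO[C@@H]1O2` reaches only a limit of the assay, giving > 50000 nM in this assay. Compound 2 `O=C1C[C@H](OCc2cn(-c3ccccc3)nn2)[C@H]2CO[C@@H]1O2` gives 25200 nM in this assay, and compound 3 `CCCCn1cc(CO[C@H]2CC(=O)[C@@H]3OC[C@H]2O3)nn1` gives 27900 nM. Compound 3 therefore holds the higher of the two numbers, but its nearest neighbour, compound 2, differs by only a 1.1-fold higher number from compound 2 to compound 3 (0.04 log units; within the scatter), a gap within the scatter, so the two cannot be placed in order. The step of an at least 1.9-fold lower number from compound 1 to compound 2 (0.29 log units; that floor lies within the scatter) arises from a phenyl in place of a benzyl on the triazole nitrogen, while an at least 1.7-fold lower number from compound 1 to compound 3 (0.25 log units; that floor lies within the scatter) reflects a propyl in place of the phenyl of the benzyl chain.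

Compound 4 `O=C1C[C@H](OCc2cn(-c3ccccc3Cl)nn2)[C@H]2CO[C@@H]1O2` is not yet measured. It differs from compound 3 as follows: 2-chlorophenyl in place of butyl on an aromatic nitrogen. The step between compound 2 and compound 3 bears most directly on this change, since it swaps an alkyl group for an aryl group on the same nitrogen and stays within the scatter. Among the compounds with values here, the 2-chlorophenyl group has no precedent among the measured compounds. A step of a 1.2-fold lower number from compound 3 to compound 4 (0.07 log units; within the scatter) is expected, with no change beyond the scatter in either direction. Compound 4 is accordingly estimated at 24000 nM in this assay, with a range from 9000 nM to 60000 nM.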

Compound 4, half-maximal inhibitory concentration: 26400 nM
Estimate against measurement, compound 4: 1.1-fold (0.04 log units) below; low and high end bracket the measured number.
By their numbers in this assay, from the lowest: compounds 2, 4 and 3 (each within the scatter of the next). At a limit, above all of these: compound 1.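

In this assay, within the data shown here, the chloro group is the first substituent seen on the aryl ring attached to the triazole nitrogen, and the step it gives, a 1.0-fold higher number from compound 2 to compound 4 (0.02 log units; within the scatter), does not separate the chlorinated compound from its unsubstituted parent. The exchange of the butyl chain for the 2-chlorophenyl group, a 1.1-fold lower number from compound 3 to compound 4 (0.02 log units; within the scatter), likewise cannot be told apart from no difference at all, so a substituted aryl group now joins phenyl and butyl among the groups on this nitrogen that give numbers within the scatter of one another. The value of the benzyl analogue is a limit of the assay, so the step to the 2-chlorophenyl group, an at least 1.8-fold lower number from compound 1 to compound 4 (0.27 log units; that floor lies within the scatter), gives only a floor that cannot place the two apart: the limit of > 50000 nM in this assay, at which 1 of the 4 values shown sits.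

The compounds shown leave open whether any group on this nitrogen can move the number beyond the scatter, for instance an amine or a carboxylic acid on the phenyl ring, or a longer chain in place of butyl. They also leave open whether chloro placed elsewhere on the phenyl ring would give a different reading.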